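Dropping the butyl chain from a weak growth inhibitor

This account rests on a few compounds, and the source may have more. Where it says the series, first, only, none or still open, it means among the compounds named here.

Measured compounds:
Compound 1, `CCCCc1cc2nn(-c3ccccc3)cc2cn1`: 13300 nM
Compound 2, `CCCCc1cc2nn(-c3ccccc3)cc2c(C)n1`: 11100 nM
Compound 3, `CCCCc1cc2nn(-c3ccccc3)cc2c(C(C)C)n1`: 33300 nM

In a functional assay on MCF7 cells (Homo sapiens) for inhibition, read by fluorescence, with a stated time of 72 h (a lower number here means a stronger inhibitor of growth, a higher number a weaker inhibitor of growth), compound 1 gives 13300 nM, the second highest of the three numbers. Its closest neighbour is compound 2, and a 1.2-fold lower number from compound 1 to compound 2 (0.08 log units; within the scatter). Compound 3 is furthest away: a 2.5-fold higher number from compound 1 to compound 3 (0.40 log units; beyond the scatter), and likewise a 3.0-fold higher number from compound 2 to compound 3 (0.48 log units; beyond the scatter). Both of these larger steps concern a growing group on one aromatic carbon of the shared core; neither touches the butyl chain.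

Compound 4, `c1ccc(-n2cc3cnccc3n2)cc1`, differs from compound 1 in just that chain: hydrogen in place of butyl on an aromatic carbon. For the measured compounds named here, no measured pair shows what removing the butyl does, so the three steps above give no direct guide. Going by the values given here, the only hint is that changes of group size on the core moved the number modestly, as a 3.0-fold higher number from compound 2 to compound 3 (0.48 log units; beyond the scatter) shows. Taking away four carbon atoms is a larger change than any measured here, so a weakening beyond the scatter is expected, with a 2.3-fold higher number from compound 1 to compound 4 (0.35 log units; beyond the scatter) as the guess. Compound 4 is therefore estimated at 30000 nM, within 8000 nM to 100000 nM.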

Compound 4, concentration for 50% growth inhibition: > 100000 nM
Compound 4: a limit, no number (the forecaster's own chance of this, stated with the estimate: 30%); middle value at least 3.3-fold (0.52 log units) away from the limit.
By their numbers in this assay, from the lowest: compounds 2 and 1 (each within the scatter of the next); then compound 3. At a limit, above all of these: compound 4.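

Hydrogen in place of butyl, on the aromatic carbon next to the ring nitrogen, gives an at least 7.5-fold higher number from compound 1 to compound 4 (0.87 log units; beyond the scatter) against a 3.0-fold higher number from compound 2 to compound 3 (0.48 log units; beyond the scatter) for the largest change made elsewhere on the shared core. Among the compounds shown, a growth-inhibition number in this assay appears only with the butyl chain in place, and compounds 1, 2 and 3, which all carry that chain, could not reveal this. Compound 4 sits at a limit of the assay, not at a number: the limit of > 100000 nM in this assay, at which 1 of the 4 values shown sits.

The compounds shown hold only butyl or hydrogen at this carbon, so it stays open whether a shorter chain such as ethyl, a longer chain such as hexyl, or an amine would keep, lose or improve growth inhibition. From the compounds shown here alone, how far compound 4 lies past its limit also stays open.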